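This account rests on a few compounds, and the source may have more. Where it says the series, first, only, none or still open, it means among the compounds named here.

Working notes on the series, read in an ADME assay on LLC-MK2 cells (Macaca mulatta) for cytotoxicity, read by MTT assay, with a stated time of 48 h; a lower number here means that less compound is tolerated, a higher number that more compound is tolerated. Compound 1 `C/C(=C\c1ccccc1)C(=O)/C=C/c1ccc(N(C)C)cc1` gives 53000 nM, compound 2 `COc1ccc(/C=C(\C)C(=O)/C=C/c2ccc(N(C)C)cc2)cc1` gives 411000 nM, and compound 3 `C/C(=C\c1ccc(N(C)C)cc1)C(=O)/C=C/c1ccc([N+](=O)[O-])cc1` lies between them at 167000 nM, the second highest of the three numbers. Next is compound 4 `C/C(=C\c1ccc(N(C)C)cc1)C(=O)/C=C/c1ccc(N(C)C)cc1`, with dimethylamino in place of nitro on an aromatic carbon. Within the data shown here, no measured step replaces nitro. Among the measured compounds shown here, the only measured step, a 7.8-fold higher number from compound 1 to compound 2 (0.89 log units; beyond the scatter), is methoxy in place of hydrogen on an aromatic carbon, so it offers a rough size for a single group change and no direction for this one. The expected step is a 1.2-fold higher number from compound 3 to compound 4 (0.08 log units; within the scatter), with no clear move beyond the scatter. For compound 4 the estimated value is 200000 nM, with an expected range of 60000 nM to 600000 nM.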

Compound 4, half-maximal cytotoxic concentration: 314000 nM
For compound 4 the middle estimate is 1.6-fold (0.20 log units) below the measured one, and the stated range covers the measured number.
By their numbers in this assay, from the lowest: compound 1; then compounds 3, 4 and 2 (each within the scatter of the next, the first and the last beyond it).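

On this aromatic carbon, para to a large group, dimethylamino in place of nitro (a 1.9-fold higher number from compound 3 to compound 4 (0.27 log units; within the scatter)) and dimethylamino in place of methoxy (a 1.3-fold lower number from compound 2 to compound 4 (0.12 log units; within the scatter)) both stay within the scatter, so these three groups are not told apart here. Only dimethylamino in place of hydrogen (a 5.9-fold higher number from compound 1 to compound 4 (0.77 log units; beyond the scatter)) moves beyond it, and in the same direction as the methoxy step (a 7.8-fold higher number from compound 1 to compound 2 (0.89 log units; beyond the scatter)). From the compounds shown here alone, whether any substituent at this position gives that rise remains open, for instance a carboxylic acid or trifluoromethyl. No measurement shown accounts for these numbers.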